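A few compounds are considered here, and "the series" means these few. Any claim that something is new, unique, unknown or untested is made for them only; others in the source may bear on it.

Measured so far:
compound 1, `CC(C)(NC(=O)COC(=O)c1ccc([N+](=O)[O-])o1)c1ccccc1` — > 100000 nM
compound 2, `CC(C)(C)N(CCC(=O)c1ccccc1)C(=O)COC(=O)c1ccc([N+](=O)[O-])o1` — "not active" (no number reported)

In an ADME assay on HEK-293T cells (Homo sapiens) for cytotoxicity, read by MTT assay, with a stated time of 3 days (a lower number here means that less compound is tolerated, a higher number that more compound is tolerated), compound 1 reaches only a limit of the assay, > 100000 nM, and not a number. Compound 2 stands without any number in this assay, where it is reported as "not active" (no number reported). Of the two values shown, one sits at the limit of > 100000 nM in this assay, at which 1 of the 2 values shown sits, and the other is given only in words, so neither compound shows a measurable half-maximal cytotoxic concentration in this assay, and the two cannot be ordered against each other.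

Compound 3, `CC(=O)Oc1ccc(CN(C(=O)COC(=O)c2ccc([N+](=O)[O-])o2)C(C)(C)C)cc1`, has not yet been measured. It differs from compound 2 in one place: 4-acetoxyphenyl in place of benzoylmethyl on a saturated chain carbon bound to an amide-type nitrogen. Among the measured compounds shown here, since both compound 1 and compound 2 stand without a number in this assay, no step between them can be sized, and for the change from compound 2 to compound 3 no shift beyond the scatter is expected in this assay in either direction. Compound 3 is therefore expected to give a half-maximal cytotoxic concentration of about 150000 nM, somewhere between 40000 nM and 500000 nM, most likely returned again as a limit rather than a number.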

Compound 3, half-maximal cytotoxic concentration: > 100000 nM
Compound 3 ended at the assay's limit; the forecaster's own chance of this, stated with the estimate: 75%; the middle value lies beyond the limit too.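

In this assay compound 3 gives > 100000 nM, which is a limit of the assay and not a number. Among the compounds shown here, compound 2 has no number there either, so no step between compound 2 and compound 3 can be read. Where the half-maximal cytotoxic concentration of compound 1, compound 2 or compound 3 actually lies stays open, and the values offer only this: the limit of > 100000 nM in this assay, at which 2 of the 3 values shown sit.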